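Swapping a ring oxygen for sulfur on an inactive pyrazole scaffold

The source may hold more compounds than are shown below. What is called first, only, known or untested is meant among the compounds shown, and "the series" means these compounds.

Compound 1 `O=S(=O)(CC1=NCCO1)c1c(-c2ccc(Cl)cc2)nn(-c2ccccc2)c1-c1ccc(Cl)cc1` and compound 2 `COc1ccc(C2=NN(c3ccccc3)C(c3ccc(C)cc3)C2S(=O)(=O)CC2=NCCO2)cc1` share no counted difference; the difference between the two cores is not broken down here. In a functional assay, read by Griess assay, with a stated time of 150 min, tested at 75 ug/mL (a lower number here means a weaker effect, a higher number a stronger effect of the compound at the concentration tested), compound 2 gives 64.9%, whereas compound 1 gives "not active" (no number reported) and so no number. Compound 3 `COc1ccc(C2=NN(c3ccccc3)C(c3ccc(C)cc3)C2S(=O)(=O)CC2=NCCS2)cc1` carries a group of 5 heavy atoms (3 carbon, 1 nitrogen, 1 sulfur; one five-membered non-aromatic ring with 2 hetero atoms) in place of a group of 5 heavy atoms (3 carbon, 1 nitrogen, 1 oxygen; one five-membered non-aromatic ring with 2 hetero atoms), on a saturated chain carbon bound to a sulfonyl sulfur and gives 44.9%, a change of a number 20 percentage points lower from compound 2 to compound 3 (beyond the scatter). Compound 4 `O=S(=O)(CC1=NCCS1)c1c(-c2ccc(Cl)cc2)nn(-c2ccccc2)c1-c1ccc(Cl)cc1` carries the same change, (a group of 5 heavy atoms (3 carbon, 1 nitrogen, 1 sulfur; one five-membered non-aromatic ring with 2 hetero atoms) in place of a group of 5 heavy atoms (3 carbon, 1 nitrogen, 1 oxygen; one five-membered non-aromatic ring with 2 hetero atoms), on a saturated chain carbon bound to a sulfonyl sulfur), made on compound 1. Since compound 1 shows no measurable effect in this assay and the same change lowered the read-out from compound 2 to compound 3, compound 4 is expected to remain weak. Compound 4 is estimated to give 10%, expected between 0% and 30%.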

Compound 4, a percentage reported as activity, at one concentration (the size of the read-out at that concentration, not a potency): "not active" (no number reported)
No number was reported for compound 4, so the estimate cannot be set against anything.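

Compound 1 and compound 4 both lack a number in this assay, so no step can be read between them, and no evidence at hand bears on this result. Going by these compounds, whether the sulfur-for-oxygen swap changes the read-out on this core at all stays open.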